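The compounds below may be only part of what the source reports. "The series", "measured", "known", "first", "only" and "open" are said of these compounds alone.

Measured so far:

Compound 1, `CCNc1nc(C)c(-c2nc3ccccc3s2)c(N[C@@H]2C[C@H](CO)[C@@H](O)[C@H]2O)n1` — in an ADME assay on the whole organism (plasma) for pharmacokinetics, with Rattus norvegicus as the target, with a stated time of 6 h, at a dose of 10 mg/kg by the oral route (on this read-out higher numbers stand for higher exposure at the dose given and lower numbers for lower exposure), compound 1 gives 2580 ng.h/mL.
Compound 2, `CCOC(=O)NCCNc1nc(C)c(-c2nc3ccccc3s2)c(N[C@@H]2C[C@H](CO)[C@@H](O)[C@H]2O)n1` — in this assay compound 2 gives 151 ng.h/mL.

Of these two values, compound 1 holds the higher one, and the gap down to compound 2 is a 17-fold lower number from compound 1 to compound 2 (1.23 log units; beyond the scatter). Among the measured compounds shown here, that single measured step is the only guide here: it came from putting (ethoxycarbonyl)amino in place of hydrogen on a saturated chain carbon, two bonds along the chain from a nitrogen on an aromatic ring, and the number fell sharply.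

Compound 3, `Cc1nc(NCc2ccsc2)nc(N[C@@H]2C[C@H](CO)[C@@H](O)[C@H]2O)c1-c1nc2ccccc2s1`, has not yet been measured. It differs from compound 1 as follows: thiophen-3-yl in place of methyl on a saturated chain carbon bound to a nitrogen on an aromatic ring. Here too the ethylamino side chain of compound 1 is changed, but with thiophen-3-yl entering in place of methyl rather than a carbamate chain entering in place of hydrogen. For the measured compounds named here, since the only step on record, from compound 1 to compound 2, was a large drop, a fall is expected for compound 3 as well, though a smaller one is judged likely, namely a 3.2-fold lower number from compound 1 to compound 3 (0.51 log units; beyond the scatter). Compound 3 is therefore estimated at 800 ng.h/mL, somewhere between 200 ng.h/mL and 2500 ng.h/mL.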

Compound 3, area under the concentration-time curve: 96.7 ng.h/mL
Estimate against measurement, compound 3: 8.3-fold (0.92 log units) above; measured number outside the range, below it.
By their numbers in this assay, from the lowest: compounds 3 and 2 (each within the scatter of the next); then compound 1.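

The drop seen with compound 2 does not depend on a carbamate chain: thiophen-3-yl in place of methyl, on the saturated chain carbon bound to a nitrogen on an aromatic ring, also gives a large fall in this assay, with a 27-fold lower number from compound 1 to compound 3 (1.43 log units; beyond the scatter) as the result. The two replacements share little beyond sitting on this same side chain, yet this measurement cannot separate them, since the comparison gives a 1.6-fold lower number from compound 2 to compound 3 (0.19 log units; within the scatter) and so both compounds sit far under compound 1 on this read-out. Nothing available here explains why exposure fell in either case.

As far as these compounds go, with only these three compounds, it remains open whether any group on this chain can match the ethyl of compound 1, or whether any change here lowers exposure. A plain amino group, a methylamino group, a phenyl ring in place of thiophen-3-yl, or a chain ending in a carboxylic acid would each help show whether the fall follows the size of the group or its particular atoms.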